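Series notes: from compound 2 towards compound 3

The source may report more compounds than this note shows. Statements on the series, on what has been measured and on what is new or still open speak of the compounds shown alone.

Within the data shown here, compound 2 `Cn1cnnc1SCC(=O)Nc1ccc(-c2nc(-c3ccccc3)c(-c3ccccc3)n2C)cc1` stands highest of the two numbers so far: in a functional assay on HT-29 cells (Homo sapiens) for cytotoxicity, read by MTT assay, with a stated time of 24 h, tested at 0.64 ug/mL (on this read-out higher numbers stand for a stronger effect at the one concentration tested and lower numbers for a weaker effect), compound 2 gives 32%. The nearest measured number is that of compound 1 `Cn1c(-c2ccc(NC(=O)CCl)cc2)nc(-c2ccccc2)c1-c1ccccc1`, which in this assay gives 7.2%. Among the measured compounds shown here, the one step between the two, a number 24.8 percentage points higher from compound 1 to compound 2 (beyond the scatter), is modest but beyond the scatter.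

Compound 3 `CCN1CCN(CC(=O)Nc2ccc(-c3nc(-c4ccccc4)c(-c4ccccc4)n3C)cc2)CC1` has not been measured. It differs from compound 2 by 4-ethylpiperazin-1-yl in place of (4-methyl-4H-1,2,4-triazol-3-yl)sulfanyl on a saturated chain carbon bound to a carbonyl carbon.

For the measured compounds named here, only the step from compound 1 to compound 2 bears on this change, and it does so indirectly: it exchanges chloro for the entering group of compound 2 at the same place, whereas the new change removes that group and installs a different one. Going by the values given here, no measured step exchanges the (4-methyl-4H-1,2,4-triazol-3-yl)sulfanyl group for anything else, so the direction cannot be read from the data. Against the magnitude of the single known step, a step of similar size in either direction would not be surprising, but the central expectation is no change beyond the scatter: the step of a number 2 percentage points lower from compound 2 to compound 3 (within the scatter) is expected to be small. For compound 3 the estimate in this assay is 30%, with a range from 8% to 55%.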

Compound 3, a percentage reported as activity, at one concentration (the size of the read-out at that concentration, not a potency): 7.4%
The estimate for compound 3 lay 22.6 percentage points above the measured number; measured number below the stated range.
By their numbers in this assay, from the lowest: compounds 1 and 3 (each within the scatter of the next); then compound 2.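

In this assay, the place on a saturated chain carbon bound to a carbonyl carbon now carries a second exchange, and a number 24.6 percentage points lower from compound 2 to compound 3 (beyond the scatter) shows that the higher number of compound 2 is lost when 4-ethylpiperazin-1-yl replaces (4-methyl-4H-1,2,4-triazol-3-yl)sulfanyl. With a number 0.2 percentage points higher from compound 1 to compound 3 (within the scatter), chloro and 4-ethylpiperazin-1-yl cannot be told apart at the one concentration tested, even though only the latter brings a ring. Among the three compounds, only the (4-methyl-4H-1,2,4-triazol-3-yl)sulfanyl group of compound 2 stands apart beyond the scatter, so carrying a ring at this place does not by itself go with the higher number, and compound 3 is the compound that goes against any such reading.

No measurement at hand offers an explanation for this difference.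

The compounds shown leave open whether the sulfur link or the five-membered aromatic ring goes with the number of compound 2, a question that methylsulfanyl or imidazol-1-yl at the same place could separate. They also leave open whether an open-chain amine such as dimethylamino would stay level with compound 3 or move towards compound 2.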